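Swapping the chlorophenyl for a cyclopentyl ring

The source may hold more compounds than are shown below. What is called first, only, known or untested is meant among the compounds shown, and "the series" means these compounds.

Two measured analogues share one core: compound 1 `COc1cc(N)c(Cl)cc1NC(=O)C1CCN(C2CCCC2)CC1` and compound 2 `COc1cc(N)c(Cl)cc1NC(=O)C1CCN(Cc2ccc(Cl)cc2)CC1`. In a functional assay on the whole organism for antagonist activity, with Mus musculus as the target (on this read-out higher numbers stand for an effect only at larger amounts of compound and lower numbers for an effect already at smaller amounts), compound 1 reaches only a limit, > 10 mg/kg. In this assay, within the data shown here, compound 2 gives 1.2 mg/kg, the only true number in the set. Among the measured compounds shown here, the one measured step, an at least 8.3-fold lower number from compound 1 to compound 2 (0.92 log units; beyond the scatter), shows what a 4-chlorobenzyl brought. Compound 3 `COc1cc(N)c(Cl)cc1NC(=O)C1CCN(CC2CCCC2)CC1` is unmeasured and differs from compound 2 by cyclopentyl in place of 4-chlorophenyl on a saturated chain carbon bound to an amine nitrogen in a ring, partly undoing that change. A higher number is therefore expected, though the limit of > 10 mg/kg in this assay, at which 1 of the 2 values shown sits, leaves its size uncertain. Compound 3 is expected to give about 6 mg/kg, between 2 mg/kg and 20 mg/kg. The expected step is a 5.0-fold higher number from compound 2 to compound 3 (0.70 log units; beyond the scatter).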

Compound 3, dose for half-maximal effect: > 10 mg/kg
Compound 3: no number, only a limit; the forecaster's own chance of this, stated with the estimate: 35%; middle value at least 1.6-fold (0.22 log units) from the limit.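

With the saturated chain carbon on the amine nitrogen kept in place, replacing only the 4-chlorophenyl with cyclopentyl gives an at least 8.3-fold higher number from compound 2 to compound 3 (0.92 log units; beyond the scatter). The earlier step changed the ring and that chain carbon together, whereas this one shows that the ring alone matters at this position in this assay. The step between compound 1 and compound 3 cannot be read: the limit of > 10 mg/kg in this assay, at which 2 of the 3 values shown sit.

The compounds shown leave open whether the chlorine or the aromatic ring itself matters more. A plain benzyl on the same nitrogen would separate the two.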